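Trading 2-bromophenyl for 4-chlorophenyl on the amide

This account rests on a few compounds, and the source may have more. Where it says the series, first, only, none or still open, it means among the compounds named here.

Among the compounds with values here, in a functional assay on HepG2 cells (Homo sapiens) for inhibition, read by MTT assay (on this read-out lower numbers stand for stronger inhibition of growth and higher numbers for weaker inhibition of growth), compound 1 `COc1cc2oc(-c3cccc(NC(=O)c4ccc(Br)cc4)c3)cc(=O)c2c(OC)c1OC` gives 8850 nM, and compound 2 `COc1cc2oc(-c3cccc(NC(=O)c4ccccc4Br)c3)cc(=O)c2c(OC)c1OC` gives 23100 nM, the higher of the two numbers so far. Within the data shown here, the one measured step, a 2.6-fold higher number from compound 1 to compound 2 (0.42 log units; beyond the scatter), comes with 2-bromophenyl in place of 4-bromophenyl on a carbonyl carbon. The next compound, compound 3 `COc1cc2oc(-c3cccc(NC(=O)c4ccc(Cl)cc4)c3)cc(=O)c2c(OC)c1OC`, differs from compound 2 at that same place: 4-chlorophenyl in place of 2-bromophenyl on a carbonyl carbon. In words, 4-chlorophenyl stands in place of 2-bromophenyl on a carbonyl carbon. Among the measured compounds shown here, only the modest step to compound 2 bears on this change, read in reverse, and no measurement yet covers 4-chlorophenyl itself. A step of similar size towards a lower number is therefore expected, with wide uncertainty. The estimate is a 2.6-fold lower number from compound 2 to compound 3 (0.41 log units; beyond the scatter). Compound 3 is expected at 9000 nM, within an estimated range of 4500 nM to 18000 nM.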

Compound 3, concentration for 50% growth inhibition: 21300 nM
Compound 3: middle estimate off by 2.4-fold (0.37 log units), on the low side; the whole stated range lies below it.
By their numbers in this assay, from the lowest: compound 1; then compounds 3 and 2 (each within the scatter of the next).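

In this assay, the identity of the halogen now proves to matter on this amide: chloro in place of bromo on an aromatic carbon gives a 2.4-fold higher number from compound 1 to compound 3 (0.38 log units; beyond the scatter). The low number of compound 1 therefore does not extend to 4-chlorophenyl, which cannot be told apart from 2-bromophenyl, with a 1.1-fold lower number from compound 2 to compound 3 (0.04 log units; within the scatter); among these three amides, only 4-bromophenyl stands apart. Nothing available explains why chloro and bromo differ here.

The compounds shown leave open whether 4-iodophenyl, 4-fluorophenyl or plain phenyl on this carbonyl carbon would fall nearer compound 1 or compound 3. They also leave open whether 2-chlorophenyl would stay level with compound 2, or whether a 4-methoxyphenyl group, which carries no halogen, could match 4-bromophenyl.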